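Trifluoromethylphenyl Position and Cell Growth Inhibition

This account rests on a few compounds, and the source may have more. Where it says the series, first, only, none or still open, it means among the compounds named here.

Measured compounds:
compound 1, `Oc1ccccc1-c1cc(-c2cccc(F)c2)cc(-c2ccccc2O)n1`: > 50000 nM
compound 2, `Oc1ccccc1-c1cc(-c2ccccc2C(F)(F)F)cc(-c2ccccc2O)n1`: 4770 nM

Compound 1 `Oc1ccccc1-c1cc(-c2cccc(F)c2)cc(-c2ccccc2O)n1` reaches only a limit of the assay in a functional assay on DU-145 cells (Homo sapiens) for inhibition (a lower number here means a stronger inhibitor, a higher number a weaker inhibitor), where compound 1 gives > 50000 nM. Among the compounds with values here, compound 2 `Oc1ccccc1-c1cc(-c2ccccc2C(F)(F)F)cc(-c2ccccc2O)n1` is the only compound with a number in this assay, where compound 2 gives 4770 nM. Within the data shown here, the one measured step, an at least 10-fold lower number from compound 1 to compound 2 (1.02 log units; beyond the scatter), is large, but it rests on a limit (the limit of > 50000 nM in this assay, at which 1 of the 2 values shown sits), so its true size is not known, and it changes the group as well as where it sits.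

Compound 3 `Oc1ccccc1-c1cc(-c2cccc(C(F)(F)F)c2)cc(-c2ccccc2O)n1` is the unmeasured compound. The change is 3-(trifluoromethyl)phenyl in place of 2-(trifluoromethyl)phenyl on an aromatic carbon, at a place opposite the ring nitrogen. Among the measured compounds shown here, no measured step changes only the place of a trifluoromethyl group. The step from compound 1 to compound 2 shows that a group on this carbon can move the number a great deal, but it does not tell in which direction this change will go. A step of modest size, toward a weaker inhibitor, is expected as a 3.1-fold higher number from compound 2 to compound 3 (0.50 log units; beyond the scatter). Compound 3 is therefore estimated at 15000 nM, with a range from 3000 nM to 60000 nM.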

Compound 3, half-maximal inhibitory concentration: > 50000 nM
Compound 3 ended at the assay's limit; the forecaster's own chance of this, stated with the estimate: 30%; at least 3.3-fold (0.52 log units) between middle value and limit.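

Moving the trifluoromethyl group on its phenyl ring, with the same atoms on the same carbon opposite the ring nitrogen, gives an at least 10-fold higher number from compound 2 to compound 3 (1.02 log units; beyond the scatter) in this assay. The place of the group on that ring therefore matters in this series, and a trifluoromethyl group alone is not enough to give a number, as 3-(trifluoromethyl)phenyl shows. In this assay compound 3 gives > 50000 nM, which is a limit of the assay and not a number. The step from compound 1 to compound 3, trifluoromethyl in place of fluoro, cannot be read, and the true size of the step to compound 3 from compound 2 also stays unknown: the limit of > 50000 nM in this assay, at which 2 of the 3 values shown sit.

With compound 2 alone giving a number, the compounds shown leave open whether the effect belongs to the trifluoromethyl group itself or to any group held in that place on the phenyl ring. A methyl, a methoxy or a chloro group in the place the trifluoromethyl holds in compound 2 would separate the two, and an amine or a carboxylic acid there would widen the comparison further.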